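Moving the fluorine on the amide aryl ring

A few compounds are considered here, and "the series" means these few. Any claim that something is new, unique, unknown or untested is made for them only; others in the source may bear on it.

Three amides built on a shared core have been measured in an assay on membranes from Cerebral cortex for displacement of a labelled ligand from Neuronal acetylcholine receptor; alpha4/beta2 (Rattus norvegicus); on this read-out lower numbers stand for stronger inhibition and higher numbers for weaker inhibition. Compound 1 `O=C(Nc1cccc(F)c1)c1cncc(N2CC3CC(C2)N3)c1` gives 0.044 nM, the lowest of the three numbers and therefore the strongest inhibition in this set. Compound 2 `COc1cc(NC(=O)c2cncc(N3CC4CC(C3)N4)c2)cc(OC)c1` gives 0.985 nM, and compound 3 `COc1ccc(NC(=O)c2cncc(N3CC4CC(C3)N4)c2)cc1OC` gives 0.828 nM; both numbers lie well above that of compound 1, beyond the usual scatter, while the two of them sit close to each other.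

The unmeasured compound 4 `O=C(Nc1ccc(F)cc1)c1cncc(N2CC3CC(C2)N3)c1` differs from compound 1 in one place only: 4-fluorophenyl in place of 3-fluorophenyl on an amide-type nitrogen. Within the data shown here, no measured pair in this set shows what such a move of the fluorine does in this assay, so there is no step to lean on. Given that compound 1 stands at 0.044 nM, the estimate for compound 4 is 0.1 nM, with a range from 0.02 nM to 0.5 nM. This means an expected step of a 2.3-fold higher number from compound 1 to compound 4 (0.36 log units; beyond the scatter), a modest weakening that may or may not exceed the scatter.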

Compound 4, inhibition constant: 0.01 nM
For compound 4 the middle estimate is 10-fold (1.00 log units) above the measured one; the whole stated range lies above it.
By their numbers in this assay, from the lowest: compound 4; then compound 1; then compounds 3 and 2 (each within the scatter of the next).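

In this assay, among these compounds, 4-fluorophenyl in place of 3-fluorophenyl on the amide-type nitrogen gives a 4.4-fold lower number from compound 1 to compound 4 (0.64 log units; beyond the scatter) and so supplies the first one-place step in this set. It shows that, with the same atoms present, moving the fluorine on this aryl ring is enough to change the number beyond the scatter. Nothing available here accounts for the difference between compound 1 and compound 4.

On these data alone, what remains open is whether fluorine itself matters at this position or only the place of a substituent on the ring. Whether plain phenyl, 4-chlorophenyl or 4-methoxyphenyl on the same nitrogen would match compound 4, and what a fluorine at a third place on the ring would do, also stays unanswered.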